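Compound 1 and its 5-fluoro-1H-indol-3-yl counterpart

The compounds below may be only part of what the source reports. "The series", "measured", "known", "first", "only" and "open" are said of these compounds alone.

In a functional assay on A549 cells (Homo sapiens) for antiproliferative activity, with a stated time of 72 h (a lower number here means a stronger inhibitor, a higher number a weaker inhibitor), compound 1 (`O=C(COc1ccc(CNC2CC=C(c3c[nH]c4cccc(F)c34)CC2)c(F)c1)NO`) gives 203 nM and holds the lower of the two numbers, while compound 2 (`Cc1[nH]c2ccccc2c1C1=CCN(Cc2ccc(OCC(=O)NO)cc2)CC1`) gives 615 nM at a gap beyond the scatter. Compound 3 (`O=C(COc1ccc(CNC2CC=C(c3c[nH]c4ccc(F)cc34)CC2)c(F)c1)NO`) has the same atoms as compound 1, joined differently (5-fluoro-1H-indol-3-yl in place of 4-fluoro-1H-indol-3-yl on a double-bonded ring carbon): 5-fluoro-1H-indol-3-yl stands in place of 4-fluoro-1H-indol-3-yl on a double-bonded ring carbon. Within the data shown here, no measured pair shows this change, so no step beyond the scatter is expected in this assay in either direction. The estimate is a step of a 1.1-fold higher number from compound 1 to compound 3 (0.03 log units; within the scatter) only. Compound 3 is estimated at 220 nM with a range from 90 nM to 550 nM expected.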

Compound 3, half-maximal inhibitory concentration: 304 nM
Beside the measured number, compound 3's estimate is 1.4-fold (0.14 log units) below it; the range from low to high includes it.
By their numbers in this assay, from the lowest: compounds 1 and 3 (each within the scatter of the next); then compound 2.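

In this assay, among these compounds, 5-fluoro-1H-indol-3-yl in place of 4-fluoro-1H-indol-3-yl on a double-bonded ring carbon gives a 1.5-fold higher number from compound 1 to compound 3 (0.18 log units; within the scatter), the first measured reading of this change. At this place, the two fluorinated groups cannot be told apart in this assay, so the fluorine's location on the indole makes no difference that the scatter allows one to read. Nothing at hand bears on why this is so.

The compounds shown leave open how 6-fluoro-1H-indol-3-yl, 5-chloro-1H-indol-3-yl or 1H-indol-3-yl without fluorine would read at this place.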